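Carboxy Added to a Short Hydroxamic Acid Chain

The source may hold more compounds than are shown below. What is called first, only, known or untested is meant among the compounds shown, and "the series" means these compounds.

Compound 1 `NCCC(=O)NO` is a small molecule built from a short carbon chain carrying an amine at one end and a hydroxamic acid at the other. In an assay on isolated protein for inhibition of tyrosine-protein kinase CSK (Homo sapiens), tested at 25 uM, in the presence of a further agent that is not named here (a lower number here means less inhibition, a higher number more inhibition at the concentration tested (going by the name of the read-out)), compound 1 gives 0%, which means no measurable inhibition at the tested concentration. Going by the values given here, its only measured neighbour is compound 2 `NCC(=O)NO`, a shorter version of the same idea, and in this assay compound 2 also gives 0%. The step between them, no change at the digits printed from compound 1 to compound 2 (within the scatter), came from placing amino in place of aminomethyl on a saturated chain carbon bound to a carbonyl carbon. Compound 1 therefore stands level with compound 2, both at the floor of the read-out.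

Compound 3 `NC(CC(=O)NO)C(=O)O` keeps the chain of compound 1 and differs by carboxy in place of hydrogen on a saturated chain carbon bound to an amine nitrogen and a saturated chain carbon. Among the compounds with values here, the only step that bears on this change is no change at the digits printed from compound 1 to compound 2 (within the scatter), which altered the same chain and moved nothing. A step of no change at the digits printed from compound 1 to compound 3 (within the scatter) is therefore expected, with no movement beyond the scatter. Compound 3 is expected to give 0%, within a range from -8% to 10%.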

Compound 3, a percentage reported as inhibition, at one concentration (the size of the read-out at that concentration, not a potency): 0%
For compound 3 middle estimate and measured number coincide at the digits printed; the measured number falls inside the stated range.
By their numbers in this assay, from the lowest: compounds 1, 2 and 3 (each within the scatter of the next).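

In this assay, placing carboxy on a saturated chain carbon bound to an amine nitrogen and a saturated chain carbon gives no change at the digits printed from compound 1 to compound 3 (within the scatter) and leaves the read-out at the floor. Going by these compounds alone, the earlier pair showed only that a change in chain length moved nothing; this step adds that a new group on the chain of compound 1, here one of 3 heavy atoms, also leaves inhibition unmeasurable at the concentration tested. With both compounds at the floor, the step cannot show whether carboxy has any influence at this position, since an effect too small to lift the read-out would look the same, and nothing measured here offers an explanation for this result.

The compounds shown leave open whether any group at this position can lift inhibition above the floor, for example a phenyl ring or a longer chain in place of carboxy. They also leave open whether the hydroxamic acid matters at all, a question that a compound with a methyl ester or a primary amide at that end of the chain could begin to address if it showed measurable inhibition.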